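Cyano in Place of Isopropyl on the Aryl Ring

The source may hold more compounds than are shown below. What is called first, only, known or untested is meant among the compounds shown, and "the series" means these compounds.

Compound 1 `CCN(Cc1cccs1)C(=O)COc1ccc(C(C)C)cc1` gives 397 nM in an assay on HEK293 cells for agonist activity at transient receptor potential cation channel subfamily M member 8 (Homo sapiens), read by fluorescence and calcium flux, with a stated time of 15 min; on this read-out lower numbers stand for an effect already at smaller amounts and higher numbers for an effect only at larger amounts of compound.
Compound 2 `Cc1ccc(OCC(=O)N(CCCO)Cc2cccs2)cc1` gives 3000 nM in this assay.
Compound 3 `Cc1ccc(OCC(=O)N(Cc2cccs2)c2ccccc2)cc1` gives 23 nM in this assay.

Compound 1 stands second highest of the three numbers. Its nearest neighbour is compound 2, whose number is higher, and its furthest is compound 3, whose number is lower; both gaps lie beyond the scatter. Among the compounds with values here, the only single-point step among the measured compounds is a 130-fold lower number from compound 2 to compound 3 (2.12 log units; beyond the scatter), a change on the amide-type nitrogen.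

Compound 4 `CCN(Cc1cccs1)C(=O)COc1ccc(C#N)cc1` differs from compound 1 at a different place: cyano in place of isopropyl on an aromatic carbon. The group enters on an aromatic carbon of a six-membered aromatic ring of carbon only, para to a large group. Within the data shown here, no measured step touches that ring; the one step known concerns the amide-type nitrogen and cannot be carried over. Among the measured compounds shown here, compound 1 is also the only compound bearing isopropyl, and the others differ from it in more than one place, so nothing shows what exchanging that group does.

The expectation for compound 4 therefore rests on little. A step beyond the scatter toward higher numbers is expected, with wide uncertainty, as a 3.8-fold higher number from compound 1 to compound 4 (0.58 log units; beyond the scatter). Compound 4 is estimated at 1500 nM, within 300 nM to 8000 nM.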

Compound 4, half-maximal effective concentration: 1990 nM
Compound 4: the middle estimate sits 1.3-fold (0.12 log units) below what was measured; measured number inside the range.
By their numbers in this assay, from the lowest: compound 3; then compound 1; then compounds 4 and 2 (each within the scatter of the next).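

In this assay, the exchange of isopropyl for cyano gives a 5.0-fold higher number from compound 1 to compound 4 (0.70 log units; beyond the scatter). This shows that the group on this aromatic carbon, para to a large group, can by itself move the number beyond the scatter, which the earlier step on the amide-type nitrogen could not show. The exchange replaces 3 heavy atoms, all carbon, with 2 heavy atoms that include a nitrogen and adds 1 hydrogen-bond acceptor, but this single pair cannot tell which of these differences matters, and no supporting measurement explains the shift.

Going by these compounds, it remains open whether the higher number reflects the loss of isopropyl or the arrival of cyano, a question that a chlorine, a methoxy or a tert-butyl group at the same place on the core of compound 1 could help to separate. Also open, on these data alone, is whether the same exchange would produce a step of similar size with the phenyl on the amide-type nitrogen of compound 3 in place of the ethyl of compound 1.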